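Pyrazine hydrazones: methoxy in place of hydrogen

The source may hold more compounds than are shown below. What is called first, only, known or untested is meant among the compounds shown, and "the series" means these compounds.

Measured compounds:
compound 1 `O=C(N/N=C/c1ccccc1)c1cnccn1` — 100%
compound 2 `O=C(N/N=C/c1cccc(F)c1)c1cnccn1` — 40%
compound 3 `O=C(N/N=C/c1ccc(F)cc1)c1cnccn1` — 71%

In an ADME assay on J774 cells (Mus musculus) for cytotoxicity, read by MTT assay, with a stated time of 48 h, tested at 150 ug/mL (a higher number here means a weaker effect of the compound at the concentration tested, a lower number a stronger effect), compound 1 gives 100%, the highest of the three numbers; compound 3 sits nearest and compound 2 furthest. Compound 4 `COc1ccccc1/C=N/NC(=O)c1cnccn1` differs from compound 1 by one change: methoxy in place of hydrogen on an aromatic carbon. Among the compounds with values here, two measured steps bear on it, both placing a group on an aromatic carbon of the same ring: a number 60 percentage points lower from compound 1 to compound 2 (beyond the scatter) and a number 29 percentage points lower from compound 1 to compound 3 (beyond the scatter). Both lowered the number, one largely and one modestly. Within the data shown here, a methoxy in place of hydrogen is therefore expected to lower the number as well, probably by a modest amount, though compound 1 offers no direct precedent for this group. For compound 4 the expected step is a number 25 percentage points lower from compound 1 to compound 4 (beyond the scatter), giving an estimate of 75% (range 45% to 100%).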

Compound 4, a percentage reported as activity, at one concentration (the size of the read-out at that concentration, not a potency): 97%
For compound 4 the middle estimate is 22 percentage points below the measured one; low and high end bracket the measured number.
By their numbers in this assay, from the lowest: compound 2; then compound 3; then compounds 4 and 1 (each within the scatter of the next).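

In this assay, methoxy in place of hydrogen, ortho to a large group on the six-membered aromatic ring, gives a number 3 percentage points lower from compound 1 to compound 4 (within the scatter). Placing a group on this ring therefore does not by itself lower the number, unlike the fluoro changes, which gave a number 60 percentage points lower from compound 1 to compound 2 (beyond the scatter) and a number 29 percentage points lower from compound 1 to compound 3 (beyond the scatter). Nothing available here explains this contrast. The compounds shown leave open whether the result follows from the methoxy group or from its place on the ring. They also leave open whether an amine or a carboxylic acid at that place would behave alike.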